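Allyloxy to hydroxy on a chalcone pair

The source may hold more compounds than are shown below. What is called first, only, known or untested is meant among the compounds shown, and "the series" means these compounds.

Compound 1 `C=CCOc1ccc(C(=O)/C=C/c2c(OC)cccc2OC)cc1` gives 96000 nM in a functional assay (Homo sapiens) for inhibition; on this read-out higher numbers stand for weaker inhibition and lower numbers for stronger inhibition.
Compound 2 `C=CCOc1ccc(C(=O)/C=C/c2cccc(OC)c2OC)cc1` gives 96000 nM in this assay.
Compound 3 `COc1cccc(OC)c1/C=C/C(=O)c1ccc(O)cc1` gives 60000 nM in this assay.

Compounds 1 and 2 are built from the same atoms joined differently; the difference between the two cores is not broken down here, and their two values are level at the digits shown. From compound 1 to compound 3 the change is hydrogen in place of allyl on an oxygen on an aromatic ring and it made a step of a 1.6-fold lower number from compound 1 to compound 3 (0.20 log units; within the scatter).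

Compound 4 `COc1cccc(/C=C/C(=O)c2ccc(O)cc2)c1OC` is not yet measured. It differs from compound 2 by hydrogen in place of allyl on an oxygen on an aromatic ring, the same change at the same place, allyloxy to hydroxy. Because a 1.6-fold lower number from compound 1 to compound 3 (0.20 log units; within the scatter) stayed within the scatter, the step from compound 2 to compound 4 is expected to be about a 1.6-fold lower number from compound 2 to compound 4 (0.20 log units; within the scatter). Compound 4 is therefore estimated at 60000 nM, between 30000 nM and 120000 nM.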

Compound 4, half-maximal inhibitory concentration: 70000 nM
For compound 4 the middle estimate is 1.2-fold (0.07 log units) below the measured one; low and high end bracket the measured number.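

On the core of compound 2, the allyloxy to hydroxy change in this assay gave a step of a 1.4-fold lower number from compound 2 to compound 4 (0.14 log units; within the scatter), and it matched the step seen on the other core: the same change on two cores in this assay, a 1.6-fold lower number (0.20 log units; within the scatter) from compound 1 to compound 3 and a 1.4-fold lower number (0.14 log units; within the scatter) from compound 2 to compound 4, 1.2-fold (0.07 log units) apart, within the scatter of two such steps. Within this pair of cores, the change therefore carries over without a detectable difference between them. It does not show that hydroxy and allyloxy differ in this assay, as neither step leaves the scatter, and two cores say nothing about any other core in the series.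

The compounds shown leave open whether a longer chain or a chain ending in a carboxylic acid on that oxygen would give a step beyond the scatter. They also leave open whether an amine on the ring would do so.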